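Removing the ring chloro from compound 3

This account rests on a few compounds, and the source may have more. Where it says the series, first, only, none or still open, it means among the compounds named here.

Of the compounds shown here, three of one series have been tested in a functional assay on MCF7 cells (Homo sapiens) for antiproliferative activity, read by MTT assay, with a stated time of 72 h; a higher number here means a weaker inhibitor, a lower number a stronger inhibitor. Compound 1 `O=c1cc(CSC(=S)N2CCCC2)oc2ccccc12` gives 35800 nM. Compound 2 `O=c1cc(CSC(=S)N2CCOCC2)oc2cc(Cl)ccc12` reaches only (the limit of > 25000 nM in this assay, at which 1 of the 3 values shown sits), so its result of > 25000 nM is a limit and not a number. Compound 3 `O=c1c(Cl)c(CSC(=S)N2CCOCC2)oc2ccccc12` gives 11100 nM, the lowest of the two numbers, with compound 1 the nearest at a gap beyond the scatter.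

Compound 4 `O=c1cc(CSC(=S)N2CCOCC2)oc2ccccc12` is the unmeasured partner of compound 3. The change is hydrogen in place of chloro on an aromatic carbon. Among the measured compounds shown here, no measured pair isolates this change, so the size of the step must be guessed from the other two compounds. Since compound 1, which also carries hydrogen at that carbon, gives 35800 nM, compound 4 is expected to sit higher than compound 3, a step of a 2.7-fold higher number from compound 3 to compound 4 (0.43 log units; beyond the scatter) in this assay, which would be beyond the scatter. Compound 4 is therefore estimated at 30000 nM, within a range from 10000 nM to 90000 nM, with a fair chance that only a limit is returned.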

Compound 4, half-maximal inhibitory concentration: 21000 nM
Estimate against measurement, compound 4: 1.4-fold (0.15 log units) above; low and high end bracket the measured number.
By their numbers in this assay, from the lowest: compounds 3, 4 and 1 (each within the scatter of the next, the first and the last beyond it).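

In this assay, among the compounds shown here, hydrogen in place of chloro on this aromatic carbon gives a 1.9-fold higher number from compound 3 to compound 4 (0.28 log units; within the scatter), so the first pair to isolate this change shows a step no larger than the scatter. Morpholin-4-yl in place of pyrrolidin-1-yl on the thiocarbonyl carbon, now also isolated, gives a 1.7-fold lower number from compound 1 to compound 4 (0.23 log units; within the scatter), which likewise stays within the scatter. The chloro on another aromatic carbon can be read only as a floor, an at least 1.1-fold lower number from compound 2 to compound 4 (0.07 log units; that floor lies within the scatter), since the result for compound 2 is a limit and not a number: the limit of > 25000 nM in this assay, at which 1 of the 4 values shown sits.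

The compounds shown leave open whether a bromo or a methoxy on this aromatic carbon would move the number beyond the scatter. They also leave open whether a piperazin-1-yl on the thiocarbonyl carbon would do so.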